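Working notes on the series: from compound 2 to compound 4

The source may report more compounds than this note shows. Statements on the series, on what has been measured and on what is new or still open speak of the compounds shown alone.

Three compounds carry numbers in a functional assay on PC-12 cells (Rattus norvegicus) for cytotoxicity, read by MTT assay, with stated times of 3 h and 2 h, tested at 1 uM; on this read-out higher numbers stand for a stronger effect at the one concentration tested and lower numbers for a weaker effect. Compound 1 `CCOC(=O)c1cc2ccc(OCCCn3cc(CNC(=O)CCCCC4CCSS4)nn3)cc2oc1=O` gives 28.3%. Compound 2 `O=C(CCCCC1CCSS1)NCc1cn(CCCCCOc2ccc3ccc(=O)oc3c2)nn1` gives 57.2%, the highest of the three numbers. Compound 3 `Cc1cc(=O)oc2cc(OCCCCCn3cc(CNC(=O)CCCCC4CCSS4)nn3)ccc12` gives 56.5%; the step of a number 0.7 percentage points lower from compound 2 to compound 3 (within the scatter) is within the scatter, so no order between compound 2 and compound 3 is claimed, whereas the gap down to compound 1 lies beyond the scatter.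

Compound 4 `O=C(CCCCC1CCSS1)NCc1cn(CCCCCOc2ccc3cc(-c4ccccc4)c(=O)oc3c2)nn1` differs from compound 2 by phenyl in place of hydrogen on an aromatic carbon. Going by the values given here, the only measured single-point step, from compound 2 to compound 3, concerned methyl in place of hydrogen on an aromatic carbon and stayed within the scatter. It bears only loosely on the present change: the entering group is phenyl rather than methyl, and it enters on a different aromatic carbon, two atoms from the ring oxygen and ortho to a group of one heavy atom. Among the compounds with values here, no measured step introduces a phenyl anywhere, so the direction of the step is open.

In this assay compound 4 is expected to stay in the neighbourhood of compound 2, at an estimated 52%, within 30% to 72%. This estimate corresponds to an expected step of a number 5.2 percentage points lower from compound 2 to compound 4 (within the scatter), not beyond the scatter, with a wide range reflecting the absence of any comparable step.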

Compound 4, a percentage reported as activity, at one concentration (the size of the read-out at that concentration, not a potency): 30.7%
The estimate for compound 4 lay 21.3 percentage points above the measured number; the measured number falls inside the stated range.
By their numbers in this assay, from the lowest: compounds 1 and 4 (each within the scatter of the next); then compounds 3 and 2 (each within the scatter of the next).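

In this assay, going by these compounds alone, phenyl in place of hydrogen on an aromatic carbon, two atoms from the ring oxygen, gives a number 26.5 percentage points lower from compound 2 to compound 4 (beyond the scatter) and is the first single-point step to lie beyond the scatter. Within the data shown here, this shows that the read-out can respond to a change on the shared core, whereas the only earlier single-point step, a number 0.7 percentage points lower from compound 2 to compound 3 (within the scatter) for methyl on a different aromatic carbon, did not separate its two compounds. Nothing available bears on why the number falls with phenyl at this position, so the step stands as an observation for this one pair.

From the compounds shown here alone, it remains open whether the step belongs to phenyl specifically or would also appear with a smaller group on the same carbon, such as methyl, or with a group of another kind, such as an amine or a carboxylic acid. Also open, going by these compounds, is whether phenyl on this carbon would give a step of similar size in the presence of the methyl of compound 3 or with a shorter chain to the triazole.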